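Shortening the chain of an epoxide ester: compound 4

This account rests on a few compounds, and the source may have more. Where it says the series, first, only, none or still open, it means among the compounds named here.

Measured so far:
compound 1 `CCCCC/C=C/CCCCCCCCCC1(C(=O)OC)CO1` — 10 mg/kg
compound 2 `CCCCCCCCCCCCCCC1(C(=O)NCCO)CO1` — 100 mg/kg
compound 3 `CCCCCCCCCCCCCCC1(C(N)=O)CO1` — 10 mg/kg

All three were tested in a functional assay on the whole organism with Rattus norvegicus as the target, in the glucose tolerance test; a higher number here means that more compound is needed for the effect, a lower number that less compound is needed. Compound 1 stands level with compound 3 at the digits given, and the two together hold the lowest numbers of the set; compound 2 stands a full step away, as the pair compound 2 and compound 3 shows: a 10-fold lower number from compound 2 to compound 3 (1.00 log units; beyond the scatter). That step is the only one measured within a single change, and it concerns the group on an amide-type nitrogen, not the long chain.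

Compound 4 `CCCCCCCCCCCC1(C(=O)OC)CO1` keeps the core of compound 1 and differs from it at the far end of the chain: ethyl in place of hept-1-en-1-yl on a saturated chain carbon, nine bonds along the chain from a saturated ring carbon. Within the data shown here, no measured pair changes the chain, so there is no step of this kind to lean on. Compound 3 carries a fully saturated chain and gives a number level with compound 1, which speaks against the double bond being needed, but it says nothing about a shorter chain. The step of a 2.0-fold higher number from compound 1 to compound 4 (0.30 log units; within the scatter) is therefore expected to be small and uncertain, leaning toward a somewhat higher number. Compound 4 is estimated at 20 mg/kg, within 5 mg/kg to 100 mg/kg.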

Compound 4, minimum effective dose: 10 mg/kg
For compound 4 the middle estimate is 2.0-fold (0.30 log units) above the measured one; the range from low to high includes it.
By their numbers in this assay, from the lowest: compounds 1, 3 and 4 (each within the scatter of the next); then compound 2.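

In this assay, among these compounds, the new pair reads no change at the digits printed from compound 1 to compound 4 (within the scatter) and is the first measured change at the far end of the chain. At this position, nine bonds along the chain from a saturated ring carbon, the double bond can go and the end group can drop from the 7 heavy atoms of hept-1-en-1-yl to the 2 of ethyl, with the read-out staying within the usual scatter of repeated measurements. Nothing available explains this result, and it describes only what the number does, not how the compounds act.

Still open, as far as these compounds go, is how far this tolerance extends, as a much shorter chain, a longer chain, or a carboxylic acid or an amine at the far end of the chain could each give a different number. From the compounds shown here alone, compound 3 and compound 4 differ in more than one place, so the effect of swapping the methyl ester for the plain amide also remains open.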